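This account rests on a few compounds, and the source may have more. Where it says the series, first, only, none or still open, it means among the compounds named here.

Of the compounds shown here, three in this set have been measured in a functional assay on MGC-803 cells (Homo sapiens) for cytotoxicity, read by MTT assay, with a stated time of 72 h (on this read-out lower numbers stand for stronger inhibition and higher numbers for weaker inhibition), and a fourth has not. Compound 1 `O=C(CCl)Nc1ccc(C(=O)/C=C/c2ccc(Br)cc2)cc1` gives 6050 nM in this assay, and compound 2 `O=C(CCl)Nc1ccc(C(=O)/C=C/c2ccc(F)cc2)cc1` gives 4680 nM. The two differ only in fluoro in place of bromo on an aromatic carbon, and the step of a 1.3-fold lower number from compound 1 to compound 2 (0.11 log units; within the scatter) lies within the scatter, so the two values cannot be told apart. Compound 3 `O=C(CSC(=S)N[C@H]1CCOC1=O)Nc1ccc(C(=O)/C=C/c2ccc(Br)cc2)cc1` carries a different core, which differs from that of compound 1 by a group of 10 heavy atoms (5 carbon, 1 nitrogen, 2 oxygen, 2 sulfur; one five-membered non-aromatic ring with 1 hetero atom) in place of one chlorine atom, on a saturated chain carbon bound to a carbonyl carbon; in this assay compound 3 gives 19600 nM, and the step of a 3.2-fold higher number from compound 1 to compound 3 (0.51 log units; beyond the scatter) is beyond the scatter, leaving compound 3 with the highest of the three numbers.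

Compound 4 `O=C(CSC(=S)N[C@H]1CCOC1=O)Nc1ccc(C(=O)/C=C/c2ccc(F)cc2)cc1` has not yet been measured. Among the compounds with values here, it differs from compound 3 by fluoro in place of bromo on an aromatic carbon, which is the same change as the one from compound 1 to compound 2: the place of the change is described in the same words for both pairs, so it is the same change made on a different core. On this basis the step from compound 3 to compound 4 is expected to be a 1.3-fold lower number from compound 3 to compound 4 (0.12 log units; within the scatter), because a 1.3-fold lower number from compound 1 to compound 2 (0.11 log units; within the scatter) lay within the scatter and gives no reason to expect a marked shift on the new core. Within the data shown here, compound 4 is therefore estimated to give 15000 nM in this assay, with a plausible range from 7000 nM to 35000 nM, an expectation that rests on the single earlier instance of the change and on the measured value of compound 3 19600 nM.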

Compound 4, half-maximal inhibitory concentration: 45700 nM
Estimate against measurement, compound 4: 3.0-fold (0.48 log units) below, and the stated range ends below it.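

In this assay, fluoro in place of bromo gives a 2.3-fold higher number from compound 3 to compound 4 (0.37 log units; beyond the scatter), so the swap that could not be told apart on the core of compound 1 produces a readable rise on the core of compound 3, and its effect does not carry unchanged from one core to the other: the same change on two cores in this assay, a 1.3-fold lower number (0.11 log units; within the scatter) from compound 1 to compound 2 and a 2.3-fold higher number (0.37 log units; beyond the scatter) from compound 3 to compound 4, 3.0-fold (0.48 log units) apart, beyond the scatter of two such steps

Seen from the other side, the larger group in place of chlorine raises the number with either halogen, the fluoro pair showing a 9.8-fold higher number from compound 2 to compound 4 (0.99 log units; beyond the scatter), but the size of that step depends on which halogen is present: the same change on two cores in this assay, a 3.2-fold higher number (0.51 log units; beyond the scatter) from compound 1 to compound 3 and a 9.8-fold higher number (0.99 log units; beyond the scatter) from compound 2 to compound 4, 3.0-fold (0.48 log units) apart, beyond the scatter of two such steps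

This shows that the two changes do not act independently in these four compounds, but it rests on a single pair of cores in one assay, and it does not show why the steps differ or which of them would be typical of the series.

The compounds shown leave open whether chloro, methoxy or plain hydrogen on that aromatic carbon would follow the fluoro or the bromo pattern on each core. They also leave open whether a smaller replacement for chlorine, such as an amine or a thioether with a short alkyl chain, would produce the same split between the two halogens.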